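From a Pyridinyl Amide to a Cyclohexyl Amide

A few compounds are considered here, and "the series" means these few. Any claim that something is new, unique, unknown or untested is made for them only; others in the source may bear on it.

Compound 1 `COc1ccc2c(c1OC)C(=O)N(Cc1cc(Br)ccc1NC(=O)c1ccccn1)C2=O` gives in an assay on CHO cells for positive allosteric modulation of metabotropic glutamate receptor 5 (Homo sapiens), read by FLIPR (on this read-out lower numbers stand for an effect already at smaller amounts and higher numbers for an effect only at larger amounts of compound), only the limit > 100000 nM. Compound 2 `O=C(Nc1ccc(Cl)cc1CN1C(=O)c2ccccc2C1=O)c1cccnc1` gives in this assay a value of 35000 nM.

Compound 2 thus holds the only number shown; compound 1 sits at the limit (the limit of > 100000 nM in this assay, at which 1 of the 2 values shown sits). Compound 3 `O=C(Nc1ccc(Cl)cc1CN1C(=O)c2ccccc2C1=O)C1CCCCC1` differs from compound 2 by cyclohexyl in place of pyridin-3-yl on a carbonyl carbon. Among the measured compounds shown here, no measured step of this kind exists here, so no direction beyond the usual scatter is expected. Compound 3 is expected at 40000 nM, between 10000 nM and 150000 nM. The expected step of a 1.1-fold higher number from compound 2 to compound 3 (0.06 log units; within the scatter) is estimated to stay within the scatter.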

Compound 3, half-maximal effective concentration: 1500 nM
Estimate against measurement, compound 3: 27-fold (1.43 log units) above; the whole stated range lies above it.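

Among the compounds shown here, on this carbonyl carbon, cyclohexyl in place of pyridin-3-yl gives a 23-fold lower number from compound 2 to compound 3 (1.37 log units; beyond the scatter) in this assay, the first measured step at this position, and it is large. A pyridin-3-yl ring is therefore not required here for an effect in this assay. Nothing measured here accounts for the size of this step.

On these data alone, it remains open whether the ring nitrogen or the aromatic ring matters more, a question that phenyl on the same carbonyl carbon could address. As far as these compounds go, the effect of cyclopentyl or an open butyl chain also remains open.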